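A few compounds are considered here, and "the series" means these few. Any claim that something is new, unique, unknown or untested is made for them only; others in the source may bear on it.

The measured compounds and their values in a functional assay on SK-N-SH cells (Homo sapiens) for cytotoxicity, read by MTT assay, with a stated time of 48 h (a higher number here means a weaker inhibitor, a lower number a stronger inhibitor), are:

compound 1, `COc1ccc2[nH]cc(C3(c4c[nH]c5ccc(OC)cc45)C(=O)Nc4ccccc43)c2c1`, giving 3900 nM
compound 2, `O=C1Nc2ccccc2C1(c1c[nH]c2ccc([N+](=O)[O-])cc12)c1c[nH]c2ccc([N+](=O)[O-])cc12`, giving 11800 nM
compound 3, `COc1ccc2[nH]cc(C3(c4c[nH]c5ccc(OC)cc45)C(=O)Nc4ccc(F)cc43)c2c1`, giving 7000 nM

Compound 3 differs from compound 1 by fluoro in place of hydrogen on an aromatic carbon. This change produced a 1.8-fold higher number from compound 1 to compound 3 (0.25 log units; within the scatter). Compound 2 has a different core from compound 1; the difference between the two cores is not broken down here. Compound 4, `O=C1Nc2ccc(F)cc2C1(c1c[nH]c2ccc([N+](=O)[O-])cc12)c1c[nH]c2ccc([N+](=O)[O-])cc12`, has not yet been measured. It differs from compound 2 by fluoro in place of hydrogen on an aromatic carbon, the same change that was made from compound 1 to compound 3, occurring twice among these compounds. The expected step is a 1.3-fold higher number from compound 2 to compound 4 (0.10 log units; within the scatter), because the same change gave a 1.8-fold higher number from compound 1 to compound 3 (0.25 log units; within the scatter). Compound 4 is therefore expected to give about 15000 nM in this assay, with a likely range from 7000 nM to 35000 nM.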

Compound 4, half-maximal inhibitory concentration: 6800 nM
For compound 4 the middle estimate is 2.2-fold (0.34 log units) above the measured one, and the stated range ends above it.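

In this assay, fluoro in place of hydrogen on an aromatic carbon gave a 1.7-fold lower number from compound 2 to compound 4 (0.24 log units; within the scatter). Each step taken alone lies within the scatter, but the two run in opposite directions and the gap between them does not: the same change on two cores in this assay, a 1.8-fold higher number (0.25 log units; within the scatter) from compound 1 to compound 3 and a 1.7-fold lower number (0.24 log units; within the scatter) from compound 2 to compound 4, 3.1-fold (0.49 log units) apart, beyond the scatter of two such steps. The change therefore did not carry over unchanged between these two cores, although this single pair shows neither what sets the difference nor how the change would behave on any further core.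

The compounds shown hold only hydrogen or fluoro at this place. They leave open whether a chloro group or an amine there would also differ between the two cores.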